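This account rests on a few compounds, and the source may have more. Where it says the series, first, only, none or still open, it means among the compounds named here.

In a functional assay on LoVo cells (Homo sapiens) for antiproliferative activity, read by sulforhodamine B assay, with a stated time of 72 h (a lower number here means a stronger inhibitor, a higher number a weaker inhibitor), compound 1 `CC(=O)N[C@@H](CSC(=S)N[C@H]1CC[C@H](NC(=S)SC[C@H](NC(C)=O)C(=O)O)CC1)C(=O)O` gives 5210 nM, while compound 2 `CCCNC(=S)SC[C@H](NC(C)=O)C(=O)O` gives 151000 nM, the higher of the two numbers and beyond the scatter from compound 1. Compound 3 `CCCCNC(=S)SC[C@H](NC(C)=O)C(=O)O` differs from compound 2 by a single change, (methyl in place of hydrogen on a saturated chain carbon, three bonds along the chain from an amide-type nitrogen), which turns propyl into butyl. Among the compounds with values here, no measured step shows the effect of this change, so only a small shift towards a lower number is expected in this assay, possibly none beyond the scatter. The expected change is a 1.5-fold lower number from compound 2 to compound 3 (0.18 log units; within the scatter). For compound 3 the estimated value is 100000 nM, within an expected range of 45000 nM to 200000 nM.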

Compound 3, half-maximal inhibitory concentration: 130000 nM
For compound 3 the middle estimate is 1.3-fold (0.11 log units) below the measured one; the measured number falls inside the stated range.
By their numbers in this assay, from the lowest: compound 1; then compounds 3 and 2 (each within the scatter of the next).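

In this assay this position now has its first measured step, a 1.2-fold lower number from compound 2 to compound 3 (0.07 log units; within the scatter) and that is all methyl in place of hydrogen does here. On a saturated chain carbon, three bonds along the chain from an amide-type nitrogen, the change from propyl to butyl therefore leaves compound 2 and compound 3 level within the scatter. No supporting measurement offers an explanation for this result. Still open, from the compounds shown here alone, is whether a longer chain, an amine or a carboxylic acid in place of butyl would move the number beyond the scatter.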